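A few compounds are considered here, and "the series" means these few. Any claim that something is new, unique, unknown or untested is made for them only; others in the source may bear on it.

Compound 1, `CNC(=O)c1cc(C(=O)N[C@H]2CC[C@H](O)CC2)n([C@@H](C)c2ccccc2)n1`: 80 nm/s
Compound 2, `CCNC(=O)c1cc(C(=O)NC)nn1[C@@H](C)c1ccccc1`: 435 nm/s
Compound 3, `CCCNC(=O)c1cc(C(=O)NC)nn1[C@@H](C)c1ccccc1`: 560 nm/s

In an ADME assay for permeability (a higher number here means that the compound crosses the layer faster, a lower number that the compound crosses the layer more slowly), compound 1 stands lowest of the three. Both replacements of the 4-hydroxycyclohexyl on the amide-type nitrogen raise the number beyond the scatter: a 5.4-fold higher number from compound 1 to compound 2 (0.74 log units; beyond the scatter) and a 7.0-fold higher number from compound 1 to compound 3 (0.85 log units; beyond the scatter). Between the two chains the difference is slight, a 1.3-fold higher number from compound 2 to compound 3 (0.11 log units; within the scatter).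

Compound 4, `CNC(=O)c1cc(C(=O)N[C@H]2CC[C@H](O)CC2)n([C@@H](C)c2cccc(C(F)(F)F)c2)n1`, differs from compound 1 in a different region: trifluoromethyl in place of hydrogen on an aromatic carbon, which reads, cut one bond further out, as phenyl to 3-(trifluoromethyl)phenyl. None of the three measured steps touches this ring, so the data give no direct guide to its size. A modest upward step is nevertheless expected, a 1.9-fold higher number from compound 1 to compound 4 (0.27 log units; within the scatter). Compound 4 is estimated at 150 nm/s, with a range from 60 nm/s to 350 nm/s.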

Compound 4, apparent permeability: 280 nm/s
Estimate against measurement, compound 4: 1.9-fold (0.27 log units) below; the measured number falls inside the stated range.
By their numbers in this assay, from the lowest: compound 1; then compounds 4, 2 and 3 (each within the scatter of the next).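

Among the compounds shown here, the ring carrying the trifluoromethyl, untouched by the earlier steps, responds in this assay: placing this group on an aromatic carbon, meta to a large group, gives a 3.5-fold higher number from compound 1 to compound 4 (0.54 log units; beyond the scatter) while the 4-hydroxycyclohexyl stays in place. The number can therefore rise beyond the scatter without any change on the amide-type nitrogen. No evidence at hand bears on the reason for this step. Going by these compounds, whether chlorine, methoxy or nitrile on this ring would give a similar step remains open, as does whether trifluoromethyl would do the same on compound 2 or compound 3.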